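The source may report more compounds than this note shows. Statements on the series, on what has been measured and on what is new or still open speak of the compounds shown alone.

Working notes on the series. Of the compounds shown here, three have been measured so far in a toxicity assay on cells (Macrophage, Mus musculus, strain BALB/c) for cytotoxicity, read by MTT assay; a higher number here means a weaker inhibitor, a lower number a stronger inhibitor. Compound 1 (`COc1cc(O)cc(O)c1C(=O)/C=C/c1ccco1`) gives 384000 nM, compound 3 (`COc1ccc(/C=C/C(=O)c2c(O)cc(O)cc2OC)cc1`) gives 166000 nM, and compound 2 (`C=CCOc1cc(OC)c(C(=O)/C=C/c2ccccc2Br)c(OCC=C)c1`) gives 5400 nM. Compound 2 therefore holds the lowest of the three numbers, and its gaps to both of the others lie beyond the scatter.

The next compound to read is compound 4 (`C=CCOc1cc(OC)c(C(=O)/C=C/c2ccc([N+](=O)[O-])cc2)c(OCC=C)c1`), which has not yet been measured in this assay. It differs from compound 2 at one place: 4-nitrophenyl in place of 2-bromophenyl on a double-bonded chain carbon bound to a double-bonded chain carbon. In words, 4-nitrophenyl stands in place of 2-bromophenyl on a double-bonded chain carbon bound to a double-bonded chain carbon, and the rest of the structure is shared.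

Within the data shown here, the series has no measured step between compounds that differ in one place, so the size of this change cannot be read from precedent. The expectation is anchored on compound 2 at 5400 nM, and the uncertainty is wide. A small move toward a higher number is expected, without clearly leaving the scatter, and the estimated change is a 1.7-fold higher number from compound 2 to compound 4 (0.22 log units; within the scatter). For compound 4 the expected value is 9000 nM, with an estimated range of 2500 nM to 35000 nM.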

Compound 4, half-maximal inhibitory concentration: 13200 nM
Compound 4: middle estimate off by 1.5-fold (0.17 log units), on the low side; the measured number falls inside the stated range.
By their numbers in this assay, from the lowest: compound 2; then compound 4; then compound 3; then compound 1.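

Among these compounds, this is the first measured step at this position: in this assay, 4-nitrophenyl in place of 2-bromophenyl on a double-bonded chain carbon bound to a double-bonded chain carbon gives a 2.4-fold higher number from compound 2 to compound 4 (0.39 log units; beyond the scatter). The earlier compounds shown here offered no pair differing in one place, so they could not show that this position responds at all when the rest of the structure is held fixed; this exchange of one substituted phenyl for another moves the number by a modest amount, and the move clears the usual scatter. Nothing at hand accounts for the size or the direction of this step, which stands for now as an observation only.

As far as these compounds go, a single step changes both the group on the phenyl ring and its printed place, so the share of each remains open, and a 4-bromophenyl or a 2-nitrophenyl compound would separate the two. Also open, from the compounds shown here alone, is how the number would respond to a different kind of group on this phenyl ring, such as an amine or a carboxylic acid.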